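Compound 1 to compound 3: isopropyl gives way to 4-methoxyphenyl

A few compounds are considered here, and "the series" means these few. Any claim that something is new, unique, unknown or untested is made for them only; others in the source may bear on it.

Among the compounds with values here, in a functional assay on MCF7 cells (Homo sapiens) for antiproliferative activity, read by MTT assay, with a stated time of 72 h (on this read-out lower numbers stand for stronger inhibition and higher numbers for weaker inhibition), compound 1 `CC(C)N1C(=O)COc2ccc(-c3cccc(NS(=O)(=O)c4ccc(F)cc4)c3)cc21` gives 26000 nM, the only actual number so far. Compound 2 `COc1ccc(N2C(=O)COc3ccc(-c4cnc5ccccc5c4)cc32)cc1` gives > 40000 nM in this assay, which is a limit of the assay and not a number. Compound 3 `COc1ccc(N2C(=O)COc3ccc(-c4cccc(NS(=O)(=O)c5ccc(F)cc5)c4)cc32)cc1` keeps the rest of compound 1 and changes one group: 4-methoxyphenyl in place of isopropyl on an amide-type nitrogen in a ring. In words, this is 4-methoxyphenyl in place of isopropyl on an amide-type nitrogen in a ring.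

Within the data shown here, compound 2 also carries 4-methoxyphenyl, but it differs from compound 3 elsewhere as well, so no measured pair isolates this change. The expectation therefore rests mainly on compound 1 at 26000 nM, with no step beyond the scatter foreseen in this assay and no direction favoured. The expected change, a 1.0-fold lower number from compound 1 to compound 3 (0.02 log units; within the scatter), is correspondingly small. A reading reported only as a limit would not be surprising. For compound 3 the estimated value is 25000 nM, with an expected range from 9000 nM to 40000 nM.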

Compound 3, half-maximal inhibitory concentration: 32400 nM
Estimate against measurement, compound 3: 1.3-fold (0.11 log units) below; the measured number falls inside the stated range.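

Working from the position on the amide-type nitrogen in a ring, the replacement of isopropyl by 4-methoxyphenyl in this assay gives a 1.2-fold higher number from compound 1 to compound 3 (0.10 log units; within the scatter), so this is the first direct reading at this position, and it shows no change that can be separated from the scatter. The entering group brings 8 heavy atoms and a six-membered aromatic ring in place of 3 heavy atoms and no ring, and this larger substituent leaves the read-out where it was, so at this level of activity the position shows no sensitivity to the swap. Compound 2 stands at a limit of the assay and not at a number, and a further loss from compound 3 would soon run into that same limit, which restricts what can be read at the weak end: the limit of > 40000 nM in this assay, at which 1 of the 3 values shown sits.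

Open, on these data alone, is whether any group on this nitrogen can move the number beyond the scatter, for instance a chain ending in an amine or a carboxylic acid. Also open, as far as these compounds go, is whether the same swap stays as flat on a more active member of the series, where a step would have more room to show.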